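Exchanging the Ring on the Amine-Bound Chain Carbon

A few compounds are considered here, and "the series" means these few. Any claim that something is new, unique, unknown or untested is made for them only; others in the source may bear on it.

Of the compounds shown here, two with a shared core have been measured. In a functional assay on MCF7 cells (Homo sapiens) for inhibition, read by MTT assay, with a stated time of 72 h (a lower number here means a stronger inhibitor of growth, a higher number a weaker inhibitor of growth), compound 1 `COc1ccc(CNCCCNS(=O)(=O)c2cc(C(F)(F)F)cc(C(F)(F)F)c2)cc1OC` gives 1900 nM. Compound 2 `O=S(=O)(NCCCNCc1ccc(Cl)c(C(F)(F)F)c1)c1cc(C(F)(F)F)cc(C(F)(F)F)c1` gives 3500 nM in this assay. Within the data shown here, the only step between them is a 1.8-fold higher number from compound 1 to compound 2 (0.27 log units; within the scatter), so the two numbers are not separated beyond the scatter, and compound 2 stands at the same level as compound 1 on the two numbers that exist.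

Compound 3 `O=S(=O)(NCCCNCC1COc2ccccc2O1)c1cc(C(F)(F)F)cc(C(F)(F)F)c1` has not yet been measured. It differs from compound 2 by 2,3-dihydro-1,4-benzodioxin-2-yl in place of 4-chloro-3-(trifluoromethyl)phenyl on a saturated chain carbon bound to an amine nitrogen. Among the measured compounds shown here, only one measured step bears on this change, the exchange at the same place on the chain carbon, and that step, a 1.8-fold higher number from compound 1 to compound 2 (0.27 log units; within the scatter), was within the scatter. For the measured compounds named here, with a single step of that size as the only guide, no step beyond the scatter is expected in this assay, and the expected step is a 1.2-fold lower number from compound 2 to compound 3 (0.07 log units; within the scatter). Compound 3 is therefore estimated at 3000 nM in this assay, with a range from 1000 nM to 9000 nM.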

Compound 3, concentration for 50% growth inhibition: 2500 nM
For compound 3 the middle estimate is 1.2-fold (0.08 log units) above the measured one; low and high end bracket the measured number.
By their numbers in this assay, from the lowest: compounds 1, 3 and 2 (each within the scatter of the next).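

In this assay, 2,3-dihydro-1,4-benzodioxin-2-yl on a saturated chain carbon bound to an amine nitrogen gives a 1.4-fold lower number from compound 2 to compound 3 (0.15 log units; within the scatter) and a 1.3-fold higher number from compound 1 to compound 3 (0.12 log units; within the scatter), and both steps lie within the scatter. Among these compounds, the earlier pair showed only one exchange of one substituted phenyl group for another, whereas this group adds a six-membered non-aromatic ring with 2 hetero atoms and has 2 hydrogen-bond acceptors, against 0 in the 4-chloro-3-(trifluoromethyl)phenyl group it replaces, and still no step beyond the scatter appears among compound 1, compound 2 and compound 3. No measurement shown here offers an explanation for this result.

Going by these compounds, all three compounds carry a ring system at this place, so it remains open whether a carboxylic acid, a pyridine ring or a simple methyl group there would give a step beyond the scatter. The shared core also stays the same throughout, which leaves open how a longer chain in place of the present one would read in this assay with any of these three groups.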